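Replacing a bromohydroxyphenyl with fluorophenyl on the hydrazone

A few compounds are considered here, and "the series" means these few. Any claim that something is new, unique, unknown or untested is made for them only; others in the source may bear on it.

Measured so far in a functional assay on PC-3 cells (Homo sapiens) for inhibition; on this read-out higher numbers stand for weaker inhibition and lower numbers for stronger inhibition:
- compound 1, `Cc1c(C(=O)N/N=C\c2cccc(F)c2)oc2cccc(O)c12`: >= 40000 nM
- compound 2, `Cc1c(C(=O)N/N=C\c2ccccc2O)oc2cccc(O)c12`: 8350 nM
- compound 3, `Cc1c(C(=O)N/N=C\c2cccc(Br)c2O)oc2cccc(O)c12`: 16600 nM

Compound 1 gives a value that is a limit of the assay rather than a number. Among the remaining two, compound 3 holds the higher number, though against compound 2 the gap is a 2.0-fold higher number from compound 2 to compound 3 (0.30 log units; within the scatter). Compound 4, `Cc1c(C(=O)N/N=C\c2ccc(F)cc2)oc2cccc(O)c12`, has not been measured; it differs from compound 3 by 4-fluorophenyl in place of 3-bromo-2-hydroxyphenyl on a carbon with a double bond to nitrogen. Among the compounds with values here, the steps that bear on this are an at least 4.7-fold lower number from compound 1 to compound 2 (0.68 log units; beyond the scatter) and an at least 2.4-fold lower number from compound 1 to compound 3 (0.38 log units; beyond the scatter), both showing that a phenyl carrying a hydroxyl gives a lower number than a fluorophenyl. Removing the hydroxyl again is therefore expected to raise the number, a 2.1-fold higher number from compound 3 to compound 4 (0.32 log units; beyond the scatter). Compound 4 is estimated at 35000 nM, between 12000 nM and 100000 nM, with a fair chance of a limit only.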

Compound 4, half-maximal inhibitory concentration: >= 40000 nM
Compound 4 ended at the assay's limit; the forecaster's own chance of this, stated with the estimate: 50%; middle value at least 1.1-fold (0.05 log units) away from the limit.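

In this assay, placing 4-fluorophenyl on this carbon with a double bond to nitrogen gives an at least 2.4-fold higher number from compound 3 to compound 4 (0.38 log units; beyond the scatter) and an at least 4.7-fold higher number from compound 2 to compound 4 (0.68 log units; beyond the scatter). The earlier drop in inhibition on losing the hydroxyl-bearing phenyl therefore holds for a second fluorophenyl, not only for 3-fluorophenyl. The step between the two fluorophenyl compounds, compound 1 and compound 4, cannot be read, because both give only a limit rather than a number: the limit of >= 40000 nM in this assay, at which 2 of the 4 values shown sit.

From the compounds shown here alone, whether an amine or a methoxy group on the phenyl would match compound 2 and compound 3 stays open.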